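A few compounds are considered here, and "the series" means these few. Any claim that something is new, unique, unknown or untested is made for them only; others in the source may bear on it.

- compound 1 `COc1ccc(/C=C/C(=O)Nc2nnc(-c3ccc(C)cc3)s2)cc1`: 0.35 ug/mL
- compound 2 `O=C(/C=C/c1ccc(F)cc1)Nc1nnc(-c2ccc(Cl)cc2)s1`: 1.58 ug/mL
- compound 3 `O=C(/C=C/c1ccccc1)Nc1nnc(-c2ccc(Cl)cc2)s1`: 1.42 ug/mL

In a functional assay on MCF7 cells (Homo sapiens) for antiproliferative activity, read by MTT assay, with a stated time of 48 h (on this read-out lower numbers stand for stronger inhibition and higher numbers for weaker inhibition), compound 3 gives 1.42 ug/mL. This lies within the scatter of compound 2, while compound 1 gives a clearly lower number, 0.35 ug/mL.

The next compound, compound 4 `COc1ccc(/C=C/C(=O)Nc2nnc(-c3ccc(Cl)cc3)s2)cc1`, is compound 3 with one change: methoxy in place of hydrogen on an aromatic carbon. In words, this is methoxy in place of hydrogen on an aromatic carbon, so phenyl becomes 4-methoxyphenyl.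

Among the measured compounds shown here, only one measured step involves a single change, a 1.1-fold lower number from compound 2 to compound 3 (0.05 log units; within the scatter). For the measured compounds named here, it swaps fluoro for hydrogen, not methoxy, so it shows only that this one swap made no measurable difference. Compound 1 does carry the 4-methoxyphenyl group and gives 0.35 ug/mL, but it also differs from compound 3 on its other aromatic ring. Going by the values given here, its gap to compound 3 therefore cannot be assigned to methoxy alone, and no measured step isolates that group. Only part of that gap is expected to carry over, which points to a modest move toward stronger inhibition.

The expected step is a 1.8-fold lower number from compound 3 to compound 4 (0.25 log units; within the scatter). For compound 4 the estimated value is 0.8 ug/mL, with an expected range from 0.3 ug/mL to 1.8 ug/mL.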

Compound 4, half-maximal inhibitory concentration: 0.91 ug/mL
For compound 4 the middle estimate is 1.1-fold (0.06 log units) below the measured one; low and high end bracket the measured number.
By their numbers in this assay, from the lowest: compound 1; then compounds 4, 3 and 2 (each within the scatter of the next).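

In this assay, methoxy in place of hydrogen gives a small step (a 1.6-fold lower number from compound 3 to compound 4 (0.19 log units; within the scatter)), and methoxy in place of fluoro gives another (a 1.7-fold lower number from compound 2 to compound 4 (0.24 log units; within the scatter)), so on this read-out hydrogen, fluoro and methoxy cannot be told apart at this place, on an aromatic carbon para to a large group. Among the compounds shown here, the picture differs on the other aromatic ring: with the 4-methoxyphenyl group kept, chloro in place of methyl gives a modest step (a 2.6-fold higher number from compound 1 to compound 4 (0.41 log units; beyond the scatter)), the only one of these new steps that lies beyond the scatter, and it isolates that single change for the first time. No measurement of another kind is available to explain any of these numbers.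

The compounds shown leave open whether a quite different group at this place, such as an amine, a carboxylic acid or a longer chain like butoxy, would shift the number beyond the scatter. They also leave open whether the step from chloro to methyl on the other ring would keep its size with plain phenyl or 4-fluorophenyl in place of the 4-methoxyphenyl group.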